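This account rests on a few compounds, and the source may have more. Where it says the series, first, only, none or still open, it means among the compounds named here.

Compound 1 `C=C(Br)C(=O)Nc1ccc(/C=C2\SC(=O)N(Cc3ccc(Cl)cc3)C2=O)cc1` was measured in a functional assay on HeLa cells (Homo sapiens) for cytotoxicity, read by cell counting, with a stated time of 4 days (a lower number here means a stronger inhibitor, a higher number a weaker inhibitor), and gave 2300 nM. Among the measured compounds shown here, that is the lowest of the two numbers so far; its only neighbour, compound 2 `Nc1ccc(/C=C2\SC(=O)N(Cc3ccc(Cl)cc3)C2=O)cc1`, gave 77000 nM in this assay, and the step between them, a 33-fold higher number from compound 1 to compound 2 (1.52 log units; beyond the scatter), is large and well beyond the scatter. That step concerns the group on the aromatic nitrogen, which compound 3 keeps intact.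

Compound 3 `C=C(Br)C(=O)Nc1ccc(/C=C2\SC(=O)N(Cc3ccc(F)cc3)C2=O)cc1` differs from compound 1 in a single place: fluoro in place of chloro on an aromatic carbon. The change turns the 4-chlorobenzyl group into a 4-fluorobenzyl group and leaves the rest of the shared core untouched. For the measured compounds named here, no measured pair in this set alters that halogen, so the one step available says nothing directly about the exchange. With no evidence pointing either way, and a swap of one halogen for another at the same aromatic carbon, the expected step of no change at the digits printed from compound 1 to compound 3 (within the scatter) is one that stays within the scatter. Compound 3 is therefore estimated at 2300 nM in this assay, with a range from 1000 nM to 5500 nM.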

Compound 3, half-maximal inhibitory concentration: 2000 nM
For compound 3 the middle estimate is 1.2-fold (0.06 log units) above the measured one; the measured number falls inside the stated range.
By their numbers in this assay, from the lowest: compounds 3 and 1 (each within the scatter of the next); then compound 2.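

The exchange gives a 1.2-fold lower number from compound 1 to compound 3 (0.06 log units; within the scatter) in this assay, so at this aromatic carbon, para to a large group, the 4-chlorobenzyl and 4-fluorobenzyl groups cannot be told apart by this read-out. The earlier pair had shown only that the group on the aromatic nitrogen matters, with a 33-fold higher number from compound 1 to compound 2 (1.52 log units; beyond the scatter); this pair adds that the halogen at the far end of the molecule, unlike that group, can be exchanged for another without a step beyond the scatter, at least for these two halogens. The compounds shown offer no measurement that would explain this outcome.

On these data alone, what remains open is how far this insensitivity reaches, since only chloro and fluoro have been seen at this carbon, and a methoxy group, a trifluoromethyl group, a carboxylic acid or a plain hydrogen there could behave quite differently. Also open, as far as these compounds go, is whether the large step on the nitrogen recurs with the 4-fluorobenzyl group in place, and whether an acetyl or unbrominated propenoyl group on that nitrogen would keep the number of compound 1.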